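The source may hold more compounds than are shown below. What is called first, only, known or untested is meant among the compounds shown, and "the series" means these compounds.

Measured so far in an ADME assay on Huh7.5.1 cells (Homo sapiens) for cytotoxicity, read by WST assay, with a stated time of 48 h; a higher number here means that more compound is tolerated, a lower number that less compound is tolerated:
Compound 1 `Cc1c(-c2ccc(Cc3ccc(OC(F)F)cc3)cc2)[nH]c2cccc(F)c2c1=O`: > 5000 nM
Compound 2 `Cc1c(-c2ccc(Cc3ccc(S(F)(F)(F)(F)F)cc3)cc2)[nH]c2cccc(F)c2c1=O`: > 5000 nM

Compound 1 stands at > 5000 nM, which is a limit and not a number. Compound 2 stands at > 5000 nM, which is likewise a limit. The two measured compounds therefore share one reading: the limit of > 5000 nM in this assay, at which 2 of the 2 values shown sit.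

Compound 3 `Cc1c(-c2ccc(Cc3ccc(N4CCCCC4)cc3)cc2)[nH]c2cccc(F)c2c1=O` has not yet been measured, and it departs from compound 2 at one place: a group of 6 heavy atoms (5 carbon, 1 nitrogen; one six-membered non-aromatic ring with 1 hetero atom) in place of a group of 6 heavy atoms (5 fluorine, 1 sulfur; no ring), on an aromatic carbon. Among the compounds with values here, only one measured step bears on this change, a step that the two limits leave unreadable from compound 1 to compound 2. It gives no size to carry over, and it involved a different pair of groups. No step beyond the scatter is therefore expected in this assay, in either direction, although this rests on thin evidence. The expected step is a number no higher from compound 2 to compound 3 (the limit leaves the size open). For compound 3 the estimated value is 5000 nM, with an expected range of 2000 nM to 12000 nM.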

Compound 3, half-maximal cytotoxic concentration: > 10000 nM
Compound 3: no number, only a limit; the forecaster's own chance of this, stated with the estimate: 70%; at least 2.0-fold (0.30 log units) between middle value and limit.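

In this assay, within the data shown here, compound 1, compound 2 and compound 3 all give limits and not numbers, and no step between them can be read. The compounds shown leave open where each true value lies and whether piperidin-1-yl, difluoromethoxy and the group in compound 2 differ at all.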